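Oxime geometry switch in a pyridinyl-piperazine series

The source may report more compounds than this note shows. Statements on the series, on what has been measured and on what is new or still open speak of the compounds shown alone.

Measured compounds:
compound 1 `Cc1cccc(/C(CCN2CCN(c3ccccn3)CC2)=N/O)c1` 2.3 nM
compound 2 `CCO/N=C(\CCN1CCN(c2cccc(OC)c2)CC1)c1ccccc1` 2680 nM
compound 3 `Cc1cccc(/C(=N\O)C(O)CN2CCN(c3ccccn3)CC2)c1` 44.8 nM

In a functional assay on HEK293 cells with D(4) dopamine receptor (Homo sapiens) as the target, read by FLIPR (on this read-out higher numbers stand for an effect only at larger amounts of compound and lower numbers for an effect already at smaller amounts), compound 3 gives 44.8 nM and holds the second highest of the three numbers. Its nearest neighbour is compound 1, whose value of 2.3 nM lies well below it, beyond the scatter, and it also carries the hydroxyl on the chain that compound 1 lacks. Compound 2, with its ethoxy oxime and methoxyphenyl piperazine, gives 2680 nM and sits far above both, also beyond the scatter.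

Compound 4 `Cc1cccc(/C(=N/O)C(O)CN2CCN(c3ccccn3)CC2)c1` has not yet been measured in this assay. It differs from compound 3 as follows: the two compounds have the same atoms and bonds; at least one stereo element is drawn with a configuration in one of them and without one in the other: 1 of 2 stereo elements differ; a double bond is drawn E in compound 3 and Z in compound 4. Nothing leaves and nothing enters; the same atoms and bonds are present and only the drawn double-bond configuration changes.

Going by the values given here, no measured pair in the set isolates such a geometry switch, so there is no step to lean on. A swap of the oxime geometry is a change of shape rather than of composition, and in the absence of a comparator the expected step is a modest one in either direction, possibly within the scatter. Compound 4 is expected to give about 30 nM, with a range from 6 nM to 150 nM. This estimate means a step of a 1.5-fold lower number from compound 3 to compound 4 (0.17 log units; within the scatter), made with little confidence.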

Compound 4, half-maximal effective concentration: 4.9 nM
Estimate against measurement, compound 4: 6.1-fold (0.79 log units) above; the measured number lies below the stated range.
By their numbers in this assay, from the lowest: compound 1; then compound 4; then compound 3; then compound 2.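

Notes on the oxime double bond: in this assay this place proves sensitive on its own, since with nothing leaving or entering, the switch from E to Z gives a 9.1-fold lower number from compound 3 to compound 4 (0.96 log units; beyond the scatter). With the Z drawing shared, hydroxy in place of hydrogen on a saturated chain carbon gives a 2.1-fold higher number from compound 1 to compound 4 (0.33 log units; beyond the scatter), a smaller step, though still beyond the scatter, so the chain hydroxy is compatible with a low number in this series when the oxime is drawn as in compound 4. The reading of the geometry switch carries one reservation, since the step rests on a comparison of drawn structures: the fact that one of compounds 3 and 4 is drawn with a defined configuration and the other without, at the place where they differ.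

Open is whether the same switch gives a step of similar size without the chain hydroxy, as no geometric partner of compound 1 is shown, and whether a methoxy or an amine can stand in place of that hydroxy on the chain. Going by these compounds alone, also open is how the ethoxy oxime of compound 2 bears on this geometry effect, as no single-place step links compound 2 to the others.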